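The compounds below may be only part of what the source reports. "The series", "measured", "known", "first", "only" and "open" are said of these compounds alone.

Compound 1 `CCCCCCCCCCc1ccc(-c2noc([C@H]3CCC[C@@H](N)C3)n2)cc1` and compound 2 `CCCCCCCCCCc1ccc(-c2noc(CC(CN)OC(C)=O)n2)cc1` share a core and differ in one group. In an assay on HeLa cells for inhibition of sphingosine-1-phosphate transporter SPNS2 (Mus musculus), read by LC-MS, tested at 2 uM (on this read-out lower numbers stand for less inhibition and higher numbers for more inhibition at the one concentration tested (going by the name of the read-out)), compound 1 gives 29%, while compound 2 gives 0%, the lowest of the two numbers; the change a number 29 percentage points lower from compound 1 to compound 2 (beyond the scatter). Compound 3 `CCCCCCCCCCc1ccc(-c2noc([C@H](N)CCCCN)n2)cc1` carries the change (a group of 7 heavy atoms (5 carbon, 2 nitrogen; no ring) in place of a group of 8 heavy atoms (5 carbon, 1 nitrogen, 2 oxygen; no ring), on an aromatic carbon), so a group with two amine donors replaces the acetoxy-bearing one. Going by the values given here, only the step from compound 1 to compound 2 bears on this, and it was modest. Compound 3 is therefore expected to rise, by a number 20 percentage points higher from compound 2 to compound 3 (beyond the scatter), to an estimated 20%, within 0% to 45%.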

Compound 3, a percentage reported as inhibition, at one concentration (the size of the read-out at that concentration, not a potency): 50%
Estimate against measurement, compound 3: 30 percentage points below, and the stated range ends below it.
By their numbers in this assay, from the lowest: compound 2; then compound 1; then compound 3.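

Replacing the acetoxy-bearing group with 1,5-diaminopentyl gives a number 50 percentage points higher from compound 2 to compound 3 (beyond the scatter) in this assay, so a ring-free group at this position does not always lose all inhibition. The same group compared with 3-aminocyclohexyl gives a number 21 percentage points higher from compound 1 to compound 3 (beyond the scatter), so the ring is not needed for the highest number among these three compounds. No available evidence explains either step.

Which feature of 1,5-diaminopentyl drives the gain stays open. So does whether a carboxylic acid in place of one amine, or a longer chain carrying both amines, would match compound 3.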